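Pyridin-3-yl for 2-methylphenyl at the cytotoxicity limit

The source may report more compounds than this note shows. Statements on the series, on what has been measured and on what is new or still open speak of the compounds shown alone.

In an ADME assay on THP-1 cells (Homo sapiens) for cytotoxicity, read by MTT assay (on this read-out lower numbers stand for higher toxicity in this test and higher numbers for lower toxicity in this test), compound 1 `Cc1nc(-c2cccnc2)sc1-c1nnc(-c2ccc(Br)cc2)o1` reads > 100 ug/mL as a limit of the assay. Compound 2 `Cc1ccccc1-c1nnc(-c2sc(-c3cccnc3)nc2C)o1` reads > 100 ug/mL and this too is a limit, not a number. The change pyridin-3-yl in place of 2-methylphenyl on an aromatic carbon puts pyridin-3-yl in place of 2-methylphenyl on an aromatic carbon and gives compound 3 `Cc1nc(-c2cccnc2)sc1-c1nnc(-c2cccnc2)o1` for testing. For the measured compounds named here, the only measured step is a step that the two limits leave unreadable from compound 1 to compound 2 and its size stays unknown, with the limit of > 100 ug/mL in this assay, at which 2 of the 2 values shown sit, as all that is seen. On that basis the expected step in this assay is a step that the limit leaves unreadable from compound 2 to compound 3 and none beyond the scatter is foreseen. Compound 3 is expected at 130 ug/mL with 60 ug/mL to 300 ug/mL as the estimated range.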

Compound 3, half-maximal cytotoxic concentration: > 100 ug/mL
Compound 3 was reported as a limit (the forecaster's own chance of this, stated with the estimate: 80%); the middle value lies beyond the limit too.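

No step among compound 1, compound 2 and compound 3 can be read in this assay, because all three values are limits, not numbers: the limit of > 100 ug/mL in this assay, at which 3 of the 3 values shown sit.

Going by these compounds, whether 4-bromophenyl, 2-methylphenyl and pyridin-3-yl differ at all in this assay stays open.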